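Phenyl in place of a substituted aryl on the ring nitrogen

A few compounds are considered here, and "the series" means these few. Any claim that something is new, unique, unknown or untested is made for them only; others in the source may bear on it.

Compound 1, `COc1ccc(C)cc1N1C(=O)CSC1c1cccc(C(=O)NCCCCc2ccccc2)c1`: 95%
Compound 2, `O=C(NCCCCc1ccccc1)c1cccc(C2OCC(=O)N2c2cccc(F)c2)c1`: 87%

Of the compounds shown here, two sharing the same amide-linked side chain have been measured so far. In a functional assay on HOS-TE85 cells (Homo sapiens) for inhibition, read by CCK-8 assay, with a stated time of 72 h, tested at 1 uM (on this read-out lower numbers stand for less inhibition and higher numbers for more inhibition at the one concentration tested (going by the name of the read-out)), compound 1 gives 95%, the highest of the two numbers. Compound 2, whose ring core carries an oxygen instead of sulfur and a different aryl group on the nitrogen, gives 87%. The gap between the two lies within the usual scatter of this assay, so no order between them can be read from these numbers.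

Compound 3, `O=C(NCCCCc1ccccc1)c1cccc(C2SCC(=O)N2c2ccccc2)c1`, is the next compound to be tested. It differs from compound 1 in one place: phenyl in place of 2-methoxy-5-methylphenyl on an amide-type nitrogen in a ring. Among the compounds with values here, no pair of measured compounds differs by this change alone, so there is no measured step to lean on. Because compound 1 gives 95% and compound 2 gives 87%, both high, the expectation is that the simpler aryl group leaves the read-out high as well, with a step from compound 1 to compound 3 of a number 10 percentage points lower from compound 1 to compound 3 (within the scatter), small and possibly not beyond the scatter. Compound 3 is therefore estimated at 85%, within a range from 62% to 97%.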

Compound 3, a percentage reported as inhibition, at one concentration (the size of the read-out at that concentration, not a potency): 96%
The estimate for compound 3 lay 11 percentage points below the measured number; low and high end bracket the measured number.
By their numbers in this assay, from the lowest: compounds 2, 1 and 3 (each within the scatter of the next).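

In this assay, the swap of 2-methoxy-5-methylphenyl for phenyl on the amide-type nitrogen in the ring gives a number 1 percentage points higher from compound 1 to compound 3 (within the scatter), the first step read at this position. For this pair, the methoxy and methyl groups on the aryl ring can go without a change in the read-out beyond the scatter, and the bare phenyl, compound 3 at 96%, keeps the inhibition at the one concentration tested; this is a statement about the size of the read-out at that concentration, not about potency. Nothing in the data shown explains why the read-out stays where it does at this position.

What the compounds shown leave open is whether a single methoxy or a single methyl on the phenyl, or a more different group there such as an amine or a carboxylic acid, would keep the read-out at this level. Also open, as far as these compounds go, are whether phenyl behaves the same way on the core of compound 2, and whether a shorter chain in place of the phenylbutyl side chain would hold up on the core of compound 3.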